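Pyrazole acid series: exchanging the aryl on the core

This account rests on a few compounds, and the source may have more. Where it says the series, first, only, none or still open, it means among the compounds named here.

Compound 1 `CCSc1sc(-n2nc(C)c(Cc3ccccc3[N+](=O)[O-])c2C(=O)O)nc1-c1ccc(Cl)c(Cl)c1` and compound 2 `COC(=O)c1c(Cc2ccccc2[N+](=O)[O-])c(C)nn1-c1nc(-c2ccc(Cl)c(Cl)c2)cs1` mark the weaker end: in a functional assay on BJAB cells (Homo sapiens) for antiproliferative activity, with a stated time of 4 days (a lower number here means that less compound is needed, a higher number that more compound is needed for the effect), compound 1 gives 59000 nM and compound 2 gives 377000 nM. Compound 3 `Cc1nn(-c2nc(-c3ccc(Cl)c(Cl)c3)c(SC(C)C)s2)c(C(=O)O)c1-c1cnccn1` gives 14000 nM in this assay, the lowest of the three numbers, and its gap to compound 1 as well as to compound 2 lies beyond the scatter. Compound 4 `Cc1nn(-c2nc(-c3ccc(Cl)c(Cl)c3)c(SC(C)C)s2)c(C(=O)O)c1-c1ccccc1Cl` differs from compound 3 in one place: 2-chlorophenyl in place of pyrazin-2-yl on an aromatic carbon. Among the measured compounds shown here, no measured pair shows this change, so the size of the step has no precedent here. A modest downward step, a 1.8-fold lower number from compound 3 to compound 4 (0.24 log units; within the scatter), is expected in this assay, with a wide band of uncertainty. Compound 4 is estimated at 8000 nM, between 2500 nM and 30000 nM.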

Compound 4, half-maximal effective concentration: 13100 nM
Beside the measured number, compound 4's estimate is 1.6-fold (0.21 log units) below it, within the range that was stated.
By their numbers in this assay, from the lowest: compounds 4 and 3 (each within the scatter of the next); then compound 1; then compound 2.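

On the aromatic carbon of the shared core, 2-chlorophenyl in place of pyrazin-2-yl gives a 1.1-fold lower number from compound 3 to compound 4 (0.03 log units; within the scatter) in this assay, so the two compounds stand within the scatter of each other. In this one pair, a carbon-only ring bearing chlorine and a ring with hetero atoms and hydrogen-bond acceptors serve alike at this position. Nothing at hand explains this flat step.

Open, going by these compounds, is how this position responds to a non-aromatic group, such as an amine or a longer alkyl chain. Also open, on these data alone, is whether chlorine matters here, which an unsubstituted phenyl would address.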